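The compounds below may be only part of what the source reports. "The series", "measured", "known", "first", "only" and "open" are said of these compounds alone.

Measured so far in a physicochemical assay for lipophilicity, read by HPLC, at pH 7.5; on this read-out higher numbers stand for higher lipophilicity and lower numbers for lower lipophilicity:
- compound 1, `CC[C@@H](Nc1c(C#N)c(-c2ccc(-c3cccc(C)c3)cc2)nc2cnccc12)C(N)=O`: 3
- compound 2, `CC[C@@H](Nc1c(C#N)c(-c2ccc(-c3cccc(Cl)c3F)cc2)nc2cnccc12)C(N)=O`: 3.1
- compound 3, `CC[C@@H](Nc1c(C#N)c(-c2ccc(-c3cnccc3C)cc2)nc2cnccc12)C(N)=O`: 2

Compound 3 holds the lowest number of the three. Compound 1 stands higher, and the move in this assay was a number 1.00 log units lower from compound 1 to compound 3 (beyond the scatter); compound 2 stands higher still, with a move of a number 1.10 log units lower from compound 2 to compound 3 (beyond the scatter). Between compound 1 and compound 2 the move was only a number 0.10 log units higher from compound 1 to compound 2 (within the scatter).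

Compound 4, `CC[C@@H](Nc1c(C#N)c(-c2ccc(-c3ccccc3NC)cc2)nc2cnccc12)C(N)=O`, has not been measured. It differs from compound 3 in one place: 2-(methylamino)phenyl in place of 4-methylpyridin-3-yl on an aromatic carbon.

Among the measured compounds shown here, two measured steps bear on this. Both earlier moves onto the 4-methylpyridin-3-yl group lowered this assay, as a number 1.00 log units lower from compound 1 to compound 3 (beyond the scatter) and a number 1.10 log units lower from compound 2 to compound 3 (beyond the scatter) show, so reversing that group, back to a six-membered aromatic ring of carbon only, is expected to move the number up again. The entering 2-(methylamino)phenyl group brings one hydrogen-bond donor that neither 3-methylphenyl nor 3-chloro-2-fluorophenyl had, so compound 4 is expected to land below compound 1 rather than match it. Compound 4 is estimated at 2.4, in the range 1.8 to 3, a step of a number 0.40 log units higher from compound 3 to compound 4 (beyond the scatter).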

Compound 4, distribution coefficient: 2.5
The estimate for compound 4 lay 0.10 log units below the measured number, and the stated range covers the measured number.
By their numbers in this assay, from the lowest: compound 3; then compound 4; then compounds 1 and 2 (each within the scatter of the next).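

In this assay, the step to 2-(methylamino)phenyl on this aromatic carbon, para to a large group, is a number 0.50 log units higher from compound 3 to compound 4 (beyond the scatter). A six-membered aromatic ring of carbon only does not by itself set the level here, as the entering group also gives a number 0.50 log units lower from compound 1 to compound 4 (beyond the scatter) and a number 0.60 log units lower from compound 2 to compound 4 (beyond the scatter). Compound 4 thus stands apart from both compound 3 and the other two compounds with a carbon-only ring, and nothing measured here accounts for these differences.

The compounds shown do not separate the effect of the methylamino group from that of where it sits on the ring. From the compounds shown here alone, a 3-(methylamino)phenyl, 2-(dimethylamino)phenyl or 2-methoxyphenyl group at this position would address that question, and the values of such compounds remain open here.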